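Pyrazoline thioureas against colon carcinoma cells: a methoxy variant

The compounds below may be only part of what the source reports. "The series", "measured", "known", "first", "only" and "open" are said of these compounds alone.

Measured compounds:
Compound 1, `Cc1ccc(C2=NN(C(=S)Nc3ccccc3)C(c3ccc4c(c3)OCCO4)C2)cc1`: > 200000 nM in a functional assay on HCT-116 cells (Homo sapiens) for antiproliferative activity, read by MTT assay, with a stated time of 48 h; a lower number here means a stronger inhibitor of growth, a higher number a weaker inhibitor of growth
Compound 2, `FC(F)(F)c1ccc(C2=NN(C(=S)Nc3ccccc3)C(c3ccc4c(c3)OCCO4)C2)cc1`: 112000 nM in this assay

Compound 1 reaches only a limit of this assay, (the limit of > 200000 nM in this assay, at which 1 of the 2 values shown sits), and gives no number. Among the measured compounds shown here, compound 2 is therefore the only compound with a measured value; its number stands alone, with no second number to rank it against. For the measured compounds named here, the one measured step, an at least 1.7-fold lower number from compound 1 to compound 2 (0.25 log units; that floor lies within the scatter), is itself bounded by a limit and not known to exceed the scatter.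

Compound 3, `COc1cccc(C2=NN(C(=S)Nc3ccccc3)C(c3ccc4c(c3)OCCO4)C2)c1`, differs from compound 2 by 3-methoxyphenyl in place of 4-(trifluoromethyl)phenyl on a carbon with a double bond to nitrogen. Going by the values given here, no measured step concerns a methoxy group or this ring position, so the step from compound 1 to compound 2 bears on it only loosely, and no step beyond the scatter is expected in either direction. Compound 3 is accordingly expected to give about 150000 nM, between 50000 nM and 400000 nM, a step of a 1.3-fold higher number from compound 2 to compound 3 (0.13 log units; within the scatter).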

Compound 3, concentration for 50% growth inhibition: > 200000 nM
Compound 3 was reported as a limit; the forecaster's own chance of this, stated with the estimate: 40%; middle value at least 1.3-fold (0.12 log units) away from the limit.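

In this assay compound 3 gives > 200000 nM, which is a limit and not a number. Replacing 4-(trifluoromethyl)phenyl with 3-methoxyphenyl on the carbon with a double bond to nitrogen gives an at least 1.7-fold higher number from compound 2 to compound 3 (0.25 log units; that floor lies within the scatter), so a second change at this position, now to a group with a different substituent and ring position, is also bounded by a limit and not known to exceed the scatter. The step between compound 1 and compound 3 cannot be read, and limits now account for most of the results at this position: the limit of > 200000 nM in this assay, at which 2 of the 3 values shown sit.

The step does not separate the methoxy group from its ring position, a question that 4-methoxyphenyl or 3-(trifluoromethyl)phenyl at this carbon would address. Also open, on these data alone, is whether an amine or a carboxylic acid on this phenyl ring would give a number clear of the scatter from that of compound 2.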